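A Thiophene for a Furan on a Diaminopyrimidine Nucleoside

This account rests on a few compounds, and the source may have more. Where it says the series, first, only, none or still open, it means among the compounds named here.

Compound 1 `Nc1nc(N)c2c(-c3ccoc3)cn([C@@H]3O[C@H](CO)[C@@H](O)[C@H]3O)c2n1`: in an ADME assay on MRC5 cells (Homo sapiens), read by MTT assay, with a stated time of 72 h (a higher number here means a weaker inhibitor, a lower number a stronger inhibitor), compound 1 reaches only the limit > 100000 nM.
Compound 2 `COc1ncnc2c1c(-c1ccsc1)cn2[C@@H]1O[C@H](CO)[C@@H](O)[C@H]1O`: in this assay compound 2 gives 75300 nM.
Compound 3 `COc1nc(N)nc2c1c(-c1ccoc1)cn2[C@@H]1O[C@H](CO)[C@@H](O)[C@H]1O`: in this assay compound 3 again reaches only the limit > 100000 nM.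

Compound 3 thus stands at the limit, with no number of its own. For the measured compounds named here, the one measured step that touches it, a step that the two limits leave unreadable from compound 1 to compound 3, is unreadable because both values sit at the limit of > 100000 nM in this assay, at which 2 of the 3 values shown sit. Compound 4 `COc1nc(N)nc2c1c(-c1ccsc1)cn2[C@@H]1O[C@H](CO)[C@@H](O)[C@H]1O` carries thiophen-3-yl in place of furan-3-yl on an aromatic carbon. Going by the values given here, no measured step bears on this exchange; compound 2, which also carries thiophen-3-yl, shows a number just short of the limit. Compound 4 is therefore expected near that limit, with a number no higher from compound 3 to compound 4 (the limit leaves the size open) meaning no step beyond the scatter. The estimate for compound 4 is 100000 nM, within 50000 nM to 200000 nM.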

Compound 4, half-maximal inhibitory concentration: > 100000 nM
Compound 4: a limit, no number; the forecaster's own chance of this, stated with the estimate: 60%; the middle value lies on the limit itself.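

Compound 4 in this assay gives a limit and not a number, so thiophen-3-yl in place of furan-3-yl does not bring this compound to a measurable value. For the compounds shown here, the step from compound 3 to compound 4 cannot be read because both values sit at one limit: the limit of > 100000 nM in this assay, at which 3 of the 4 values shown sit. The one readable step, amino in place of hydrogen, is an at least 1.3-fold higher number from compound 2 to compound 4 (0.12 log units; that floor lies within the scatter), so it does not establish a change beyond the scatter.

On these data alone, whether a phenyl group or a longer alkyl chain on this aromatic carbon would give a number in this assay stays open. As far as these compounds go, the true size of the exchange of furan-3-yl for thiophen-3-yl also stays open.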